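Swapping a hydroxynaphthyl for a methoxynaphthyl on the core

The source may report more compounds than this note shows. Statements on the series, on what has been measured and on what is new or still open speak of the compounds shown alone.

Compound 1 `N#CC1=C(N)N(c2ccc(S(N)(=O)=O)cc2)C2=C(C(=O)CCC2)C1/C=C/c1ccccc1` gives > 100 ug/mL in a functional assay on Ehrlich cells (Mus musculus) for antiproliferative activity, read by trypan blue exclusion, with a stated time of 2 h (a lower number here means a stronger inhibitor, a higher number a weaker inhibitor), a limit of the assay rather than a number.
Compound 2 `N#CC1=C(N)N(c2ccc(S(N)(=O)=O)cc2)C2=C(C(=O)CCC2)C1c1cccc([N+](=O)[O-])c1` gives 25 ug/mL in this assay.
Compound 3 `N#CC1=C(N)N(c2ccc(S(N)(=O)=O)cc2)C2=C(C(=O)CCC2)C1c1c(O)ccc2ccccc12` gives > 100 ug/mL in this assay, again only a limit.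

Compound 3 therefore sits at the limit of > 100 ug/mL in this assay, at which 2 of the 3 values shown sit, with no number of its own. Compound 4 `COc1ccc(C2C(C#N)=C(N)N(c3ccc(S(N)(=O)=O)cc3)C3=C2C(=O)CCC3)c2ccccc12` differs from it in one place: 4-methoxynaphthalen-1-yl in place of 2-hydroxynaphthalen-1-yl on a saturated ring carbon. Among the compounds with values here, no measured step changes a naphthyl group this way. The steps at hand are an at least 4.0-fold lower number from compound 1 to compound 2 (0.60 log units; beyond the scatter) and an at least 4.0-fold higher number from compound 2 to compound 3 (0.60 log units; beyond the scatter), while a step that the two limits leave unreadable from compound 1 to compound 3. They only show that the group on this saturated ring carbon can move the number beyond the scatter, without saying which way a methoxy-for-hydroxy swap should go. Compound 4 is thus expected to stay close to the limit, with a number no higher from compound 3 to compound 4 (the limit leaves the size open) as the guess. Compound 4 is estimated at 100 ug/mL, within 35 ug/mL to 300 ug/mL.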

Compound 4, half-maximal inhibitory concentration: 70 ug/mL
Compound 4: middle estimate off by 1.4-fold (0.15 log units), on the high side, within the range that was stated.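

Within the data shown here, compound 4 gives the first actual number for a naphthyl group on this saturated ring carbon, so such a group does not always leave the read-out at the limit of this assay. Even so, the measured comparison is a 2.8-fold higher number from compound 2 to compound 4 (0.45 log units; beyond the scatter), which favours the 3-nitrophenyl group. Against the limits, an at least 1.4-fold lower number from compound 3 to compound 4 (0.15 log units; that floor lies within the scatter) and an at least 1.4-fold lower number from compound 1 to compound 4 (0.15 log units; that floor lies within the scatter) are only floors and establish no change.

Compound 1 and compound 3 have no number of their own: the limit of > 100 ug/mL in this assay, at which 2 of the 4 values shown sit.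

The swap changes both the oxygen group and its place on the naphthyl, so the compounds shown cannot separate those two changes. On these data alone, a 2-methoxynaphthalen-1-yl group would separate them, while the effect of an amine on the naphthyl remains open.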